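The compounds below may be only part of what the source reports. "The series", "measured", "known", "first", "only" and "open" are said of these compounds alone.

In an assay on Sf9 cells for inhibition of histone deacetylase 11 (Homo sapiens), read by fluorescence, tested at 0.5 uM (a lower number here means less inhibition, a higher number more inhibition at the concentration tested (going by the name of the read-out)), two compounds have been measured. Compound 1 `O=C(NO)c1ccc(-c2cn([C@@H]3C[C@H](C(=O)O)N(CCCc4ccccc4)C3)nn2)cc1` sits at a limit of the assay: in this assay compound 1 gives < 10%, which is a limit and not a number. Among the compounds with values here, compound 2 `O=C(NO)c1ccc(-c2cn([C@@H]3C[C@@H](CO)N(CCCc4ccccc4)C3)nn2)cc1` is the one compound with a number: in this assay compound 2 gives 14%. That is the only number shown, and the one further value shown is a limit, (the limit of < 10% in this assay, at which 1 of the 2 values shown sits), so compound 2 cannot be placed above or below anything else in a measured order. Compound 3 `O=C(NO)c1ccc(-c2cn([C@@H]3C[C@H](CO)N(CCCc4ccccc4)C3)nn2)cc1` remains to be measured. the two compounds have the same atoms and bonds and differ only in configuration as drawn: 1 of 2 stereo elements differ; a stereocentre at a saturated ring carbon is drawn S in compound 2 and R in compound 3 No step between two measured compounds is shown, so the change of configuration at a saturated ring carbon has no measured precedent here. The expected step from compound 2 to compound 3 in this assay is a number 2 percentage points lower from compound 2 to compound 3 (within the scatter), nothing beyond the usual scatter. Compound 3 is expected to give about 12%, within a range of 4% to 25%.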

Compound 3, a percentage reported as inhibition, at one concentration (the size of the read-out at that concentration, not a potency): 15%
For compound 3 the middle estimate is 3 percentage points below the measured one, within the range that was stated.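

In this assay the configuration at this saturated ring carbon now has a measured step, a number 1 percentage points higher from compound 2 to compound 3 (within the scatter), and this comparison isolates configuration alone: the fact that compounds 2 and 3 differ only in the configuration as drawn. Compound 1 stands at a limit and not a number, < 10%. Hydroxymethyl in place of carboxy on a saturated ring carbon gives a number at least 5 percentage points higher from compound 1 to compound 3 (that floor lies within the scatter), a step read from that limit: the limit of < 10% in this assay, at which 1 of the 3 values shown sits.

The compounds shown leave open whether the read-out in this assay would move with an amine, a methyl ester or a longer hydroxyalkyl chain in place of hydroxymethyl. They also leave open whether the configuration would count with carboxy in that place.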